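Replacing the piperazinone of compound 3 with a sulfopropylamine

A few compounds are considered here, and "the series" means these few. Any claim that something is new, unique, unknown or untested is made for them only; others in the source may bear on it.

Of the compounds shown here, three sharing one core have been measured in an assay on isolated protein for displacement of a labelled ligand from 5-hydroxytryptamine receptor 6 (Homo sapiens); on this read-out higher numbers stand for weaker inhibition and lower numbers for stronger inhibition. Compound 1 `O=C(NC[C@@H]1CCCc2cc(S(=O)(=O)c3cccc(F)c3)ccc21)c1ccc[nH]1` gives 5.01 nM. Compound 2 `O=C(NC[C@@H]1CCCc2cc(S(=O)(=O)c3cccc(F)c3)ccc21)[C@H]1CCCN1` gives 0.631 nM. Compound 3 `O=C1CN(C[C@@H]2CCCc3cc(S(=O)(=O)c4cccc(F)c4)ccc32)CCN1` gives 6.31 nM, the highest number of the three; its gap to compound 1 lies within the scatter, while a 10-fold higher number from compound 2 to compound 3 (1.00 log units; beyond the scatter) lies beyond it.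

Compound 4 `O=S(=O)(O)CCCNC[C@@H]1CCCc2cc(S(=O)(=O)c3cccc(F)c3)ccc21` differs from compound 3 in one place: (3-sulfopropyl)amino in place of 3-oxopiperazin-1-yl on a saturated chain carbon bound to a saturated ring carbon. The two measured steps that touch this same position are a 1.3-fold higher number from compound 1 to compound 3 (0.10 log units; within the scatter), which stays within the scatter, and a 10-fold higher number from compound 2 to compound 3 (1.00 log units; beyond the scatter), a modest change. For the measured compounds named here, both replace a carbonyl-linked group with the piperazinone; neither introduces an open chain carrying a sulfonic acid, so no measured step directly matches the change to compound 4. Given that changes at this position have so far moved this assay by a modest amount at most, the expected step is a 4.0-fold higher number from compound 3 to compound 4 (0.60 log units; beyond the scatter), toward a higher number, with wide uncertainty because the new group has no measured precedent here.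

Compound 4 is therefore estimated at 25 nM, with a range from 4 nM to 160 nM.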

Compound 4, inhibition constant: 1.26 nM
The estimate for compound 4 lay 20-fold (1.30 log units) above the measured number, outside the stated range (below it).
By their numbers in this assay, from the lowest: compounds 2 and 4 (each within the scatter of the next); then compounds 1 and 3 (each within the scatter of the next).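

In this assay, the open (3-sulfopropyl)amino chain gives a 5.0-fold lower number from compound 3 to compound 4 (0.70 log units; beyond the scatter), showing that this saturated chain carbon tolerates a group with no ring and a terminal sulfo group, something the earlier amides and the piperazinone could not reveal. The same chain also holds up against the amides: 3-sulfopropyl on the amine nitrogen gives a 4.0-fold lower number from compound 1 to compound 4 (0.60 log units; beyond the scatter) relative to the pyrrole amide, and a 2.0-fold higher number from compound 2 to compound 4 (0.30 log units; within the scatter) relative to the pyrrolidine amide, so a carbonyl-linked ring is not needed here for a number in the range of compound 2. No evidence is available to explain why this change lowers the number.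

The compounds shown leave open which part of the new group accounts for the step, the sulfo group or the open chain, a question that a plain propylamine or a carboxylic acid on the same propyl chain could help to separate. They also leave open how much the chain length matters, which a longer chain such as 4-sulfobutyl on the same amine nitrogen could address.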